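The source may report more compounds than this note shows. Statements on the series, on what has been measured and on what is new or still open speak of the compounds shown alone.

In an ADME assay on Vero cells (Chlorocebus sabaeus) for cytotoxicity, read by MTT assay, with a stated time of 96 h (a lower number here means that less compound is tolerated, a higher number that more compound is tolerated), compound 1 (`COc1ccc(-c2nc3cc(C(C)=O)ccc3[nH]2)c(OC)c1`) gives > 100000 nM, which is a limit of the assay and not a number. Compound 2 (`COc1ccc(-c2nc3cc(C(C)O)ccc3[nH]2)c(OC)c1`) gives > 100000 nM in this assay, which is likewise a limit, so compound 2 has no numerical place in the series. For the measured compounds named here, the only measured step is a step that the two limits leave unreadable from compound 1 to compound 2. That step was made at the same aromatic carbon that changes next, but it supplies no size to carry forward. The remaining evidence is the limit of > 100000 nM in this assay, at which 2 of the 2 values shown sit.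

Compound 3 (`COc1ccc(-c2nc3cc(/C(C)=N/O)ccc3[nH]2)c(OC)c1`) keeps the core of compound 2 and changes only that substituent: a group of 4 heavy atoms (2 carbon, 1 nitrogen, 1 oxygen; no ring) in place of a group of 3 heavy atoms (2 carbon, 1 oxygen; no ring), on an aromatic carbon. With no readable step to draw on, the expectation rests on compound 2 and its limit of > 100000 nM, and no shift in either direction is expected beyond the scatter. The estimated step is a number no higher from compound 2 to compound 3 (the limit leaves the size open). A further report of a limit is expected to be the more likely result. For compound 3 the estimated half-maximal cytotoxic concentration is 100000 nM, with an expected range from 30000 nM to 300000 nM.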

Compound 3, half-maximal cytotoxic concentration: > 100000 nM
Compound 3 was reported as a limit (the forecaster's own chance of this, stated with the estimate: 75%); the middle value sits exactly at the limit.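

In this assay compound 3 gives > 100000 nM, which is a limit and not a number. For the compounds shown here, the steps among compound 1, compound 2 and compound 3 therefore cannot be read, and no new step follows. The compounds shown leave open whether any substituent at this aromatic carbon would give a numerical half-maximal cytotoxic concentration: the limit of > 100000 nM in this assay, at which 3 of the 3 values shown sit.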